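From a saturated ring to an aromatic one on the amine

The source may report more compounds than this note shows. Statements on the series, on what has been measured and on what is new or still open speak of the compounds shown alone.

Compound 2 `CC1CCC(Nc2nc(C(F)(F)F)ccc2CNC(=O)C(C)c2ccc(NS(C)(=O)=O)c(F)c2)CC1` gives 27.2 nM in a functional assay on CHO-K1 cells for antagonist activity at transient receptor potential cation channel subfamily V member 1 (Homo sapiens), read by FLIPR (on this read-out higher numbers stand for weaker inhibition and lower numbers for stronger inhibition), the higher of the two numbers available. Within the data shown here, its only comparator is compound 1 `CCCCNc1nc(C(F)(F)F)ccc1CNC(=O)C(C)c1ccc(NS(C)(=O)=O)c(F)c1`, which gives 9.1 nM in this assay. Among the measured compounds shown here, the single step joining them, a 3.0-fold higher number from compound 1 to compound 2 (0.48 log units; beyond the scatter), is modest and beyond the scatter. Compound 3 `Cc1ccc(Cl)cc1Nc1nc(C(F)(F)F)ccc1CNC(=O)C(C)c1ccc(NS(C)(=O)=O)c(F)c1` has not been measured; it differs from compound 2 by 5-chloro-2-methylphenyl in place of 4-methylcyclohexyl on a nitrogen on an aromatic ring. For the measured compounds named here, no measured step exchanges a six-membered non-aromatic ring for a six-membered aromatic ring at this nitrogen, so the change is unprecedented within this small set. Going by the values given here, the only step at this place, a 3.0-fold higher number from compound 1 to compound 2 (0.48 log units; beyond the scatter), swaps one saturated group for another and bears on compound 3 indirectly: it shows that the group on this nitrogen moves the number by a modest amount while activity is retained. The shared core, with its trifluoromethyl, amide and methanesulfonamide, is unchanged. A small step is therefore expected, a 1.4-fold lower number from compound 2 to compound 3 (0.13 log units; within the scatter), with either direction possible. Compound 3 is estimated at 20 nM in this assay, within a range of 5 nM to 80 nM.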

Compound 3, inhibition constant: 14 nM
Estimate against measurement, compound 3: 1.4-fold (0.15 log units) above; measured number inside the range.
By their numbers in this assay, from the lowest: compounds 1, 3 and 2 (each within the scatter of the next, the first and the last beyond it).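

Compound 3 shows that the nitrogen on an aromatic ring also accepts a six-membered aromatic ring of carbon only: in this assay the exchange of 4-methylcyclohexyl for 5-chloro-2-methylphenyl gives a 1.9-fold lower number from compound 2 to compound 3 (0.29 log units; within the scatter) and so cannot be told from no change at all. Set against the open chain, the exchange of butyl for 5-chloro-2-methylphenyl gives a 1.5-fold higher number from compound 1 to compound 3 (0.19 log units; within the scatter) and is likewise within the scatter. Compound 3 therefore cannot be separated from either compound 1 or compound 2, even though those two stand apart from each other, so a butyl chain, a saturated ring and a substituted aromatic ring all retain activity at this place. No measurement offered here explains these numbers.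

Compound 3 brings in the aromatic ring, the chlorine and the methyl at once, so the compounds shown cannot assign any share of the result to one of them. On these data alone, it also remains open how a plain phenyl would read at this nitrogen, or a group bearing an amine or a carboxylic acid.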